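This account rests on a few compounds, and the source may have more. Where it says the series, first, only, none or still open, it means among the compounds named here.

Measured compounds:
Compound 1, `COc1ccc(C2=NN(c3ccc(Cl)cc3)C(c3ccc(Cl)cc3)C2)cc1OC`, gives 39.4%.
Compound 2, `COc1ccc(C2=NN(c3ccc(Cl)cc3)C(c3ccc(Cl)cc3)C2)cc1`, gives 23%.

Both numbers come from an assay on HEK293 cells for inhibition of protein kinase C zeta type (Homo sapiens), read by 33P incorporation, with a stated time of 40 min, tested at 20 uM, in the presence of a further agent that is not named here; on this read-out lower numbers stand for less inhibition and higher numbers for more inhibition at the one concentration tested (going by the name of the read-out). For the measured compounds named here, compound 2 stands lowest of the two, and the one step known in this assay runs from it: a number 16.4 percentage points lower from compound 1 to compound 2 (beyond the scatter). Compound 3, `COc1cccc(C2=NN(c3ccc(Cl)cc3)C(c3ccc(Cl)cc3)C2)c1`, has not yet been measured. It differs from compound 2 in one place: 3-methoxyphenyl in place of 4-methoxyphenyl on a carbon with a double bond to nitrogen. The methoxy group thus stays, and only the ring position it occupies changes.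

Going by the values given here, no measured step bears directly on this kind of change. Among the compounds with values here, the one known step, from compound 1 to compound 2, concerns the removal of a methoxy group rather than its move, and it was modest. Because compound 2 gives 23%, and the change to compound 3 keeps the same atoms, no step beyond the scatter is expected; the step from compound 2 to compound 3 is estimated as a number 2 percentage points higher from compound 2 to compound 3 (within the scatter). Compound 3 is therefore expected to give about 25%, within a range from 5% to 45%.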

Compound 3, a percentage reported as inhibition, at one concentration (the size of the read-out at that concentration, not a potency): 17.9%
Beside the measured number, compound 3's estimate is 7.1 percentage points above it, within the range that was stated.
By their numbers in this assay, from the lowest: compounds 3 and 2 (each within the scatter of the next); then compound 1.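

In this assay, 3-methoxyphenyl in place of 4-methoxyphenyl on the carbon with a double bond to nitrogen gives a number 5.1 percentage points lower from compound 2 to compound 3 (within the scatter) and so, at the level of this read-out, the two placings of a single methoxy group cannot be told apart. The new comparison with the dimethoxy compound gives a number 21.5 percentage points lower from compound 1 to compound 3 (beyond the scatter) and, together with the earlier step, shows that taking away either methoxy group of compound 1 lowers the number by more than the scatter. No measurement available here accounts for this pattern among the three compounds.

The compounds shown leave open what a plain phenyl ring with no methoxy group would give, and whether an ethoxy group, a hydroxyl group or an amine on that ring would behave as methoxy does. They also leave open whether replacing either 4-chlorophenyl group, for instance with a carboxylic acid-bearing phenyl ring, would move the number, and how these compounds would compare across a range of concentrations rather than at a single one.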